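A few compounds are considered here, and "the series" means these few. Any claim that something is new, unique, unknown or untested is made for them only; others in the source may bear on it.

Measured so far:
Compound 1, `CCCC[C@@H](C)C[C@@H](C)C(=O)N(C)[C@@H](CC(C)C)C(=O)N[C@H](C(=O)N(C)[C@H](C(=O)N1C[C@@H](O)C[C@H]1C(=O)N1C(=O)C=C[C@@H]1C)C(C)C)[C@@H](C)OC(=O)CC`: 200 nM
Compound 2, `CCCC[C@@H](C)C[C@@H](C)C(=O)N(C)[C@@H](CC(C)C)C(=O)N[C@H](C(=O)N(C)[C@H](C(=O)N1CCC[C@H]1C(=O)N1C(=O)C=C[C@@H]1C)C(C)C)[C@@H](C)O`: 650 nM

In a functional assay on NCI-H460 cells (Homo sapiens) for cytotoxicity, read by MTT assay, with a stated time of 48 h (on this read-out lower numbers stand for stronger inhibition and higher numbers for weaker inhibition), compound 1 gives 200 nM, and compound 2 gives 650 nM. Compound 2 thus stands at the higher of the two numbers, and the gap to compound 1 lies beyond the usual scatter. Among the measured compounds shown here, the two compounds differ in two places at once, so no single step between them can be read off.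

The piece now follows the step from compound 2 to compound 3, `CCCC[C@@H](C)C[C@@H](C)C(=O)N(C)[C@@H](CC(C)C)C(=O)N[C@H](C(=O)N(C)[C@H](C(=O)N1C[C@@H](O)C[C@H]1C(=O)N1C(=O)C=C[C@@H]1C)C(C)C)[C@@H](C)O`. The change is hydroxy in place of hydrogen on a saturated ring carbon. Compound 3 carries the same hydroxy on the five-membered ring as compound 1 while keeping the free alcohol of compound 2, so it sits between the two measured compounds in structure.

For the measured compounds named here, no step of this kind has been measured here. The account expects the hydroxy to move the number toward that of compound 1, a small step, at the edge of the scatter, in the direction of stronger inhibition, a 1.9-fold lower number from compound 2 to compound 3 (0.27 log units; within the scatter). Compound 3 is therefore estimated at 350 nM, within a range from 120 nM to 1000 nM.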

Compound 3, half-maximal inhibitory concentration: 75 nM
The estimate for compound 3 lay 4.7-fold (0.67 log units) above the measured number; measured number outside the range, below it.
By their numbers in this assay, from the lowest: compound 3; then compound 1; then compound 2.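

The hydroxy in place of hydrogen, on a saturated ring carbon of the five-membered non-aromatic ring and two ring bonds from the ring nitrogen, proves to be far from a minor change: in this assay it gives an 8.7-fold lower number from compound 2 to compound 3 (0.94 log units; beyond the scatter). This position on the ring is therefore one where a single added oxygen moves the number well beyond the scatter, with the free alcohol present on the other side of the molecule. Compound 3 also opens a second comparison, since hydrogen in place of propanoyl on an oxygen on a saturated carbon, with the ring hydroxy kept, gives a 2.7-fold lower number from compound 1 to compound 3 (0.43 log units; beyond the scatter), which makes compound 3 the most potent of the three in this assay.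

The compounds shown leave open whether a methoxy group, an amine or a fluorine on the same ring carbon would move the number as the hydroxy does, and whether an acetyl group on the oxygen would behave as propanoyl does. Nothing measured here explains either step.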